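The compounds below may be only part of what the source reports. "The series", "measured", "known", "first", "only" and "open" are said of these compounds alone.

Of the compounds shown here, three of one shared core have been measured. Compound 1 `CC(C)=C1C(=O)N(c2ccc(Cl)cc2)N(c2ccc(Cl)cc2)C1=O` gives, in a functional assay on MGC-803 cells (Homo sapiens) for cytotoxicity, read by MTT assay, with a stated time of 72 h (a higher number here means a weaker inhibitor, a lower number a stronger inhibitor), a value of 39000 nM. Going by the values given here, compound 2 `CCC(C)=C1C(=O)N(c2ccc(Cl)cc2)N(c2ccc(Cl)cc2)C1=O` gives 66500 nM in this assay, and the only single-point step measured, a 1.7-fold higher number from compound 1 to compound 2 (0.23 log units; within the scatter), is small. Compound 3 `O=C1C(=Cc2cccc(Cl)c2)C(=O)N(c2ccc(Cl)cc2)N1c1ccc(Cl)cc1` gives 14400 nM in this assay, the lowest of the three numbers: its gap to compound 1 is the nearer one and its gap to compound 2 the further one, both beyond the scatter.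

Compound 4 `O=C1C(=Cc2c[nH]c3ccccc23)C(=O)N(c2ccc(Cl)cc2)N1c1ccc(Cl)cc1` differs from compound 3 in one place: 1H-indol-3-yl in place of 3-chlorophenyl on a double-bonded chain carbon bound to a double-bonded ring carbon. Among the compounds with values here, the one measured step concerns an alkyl change on the chain carbon and says nothing about exchanging one aromatic group for another, so no measured step bears directly on this change. Compound 4 is therefore expected to sit near compound 3, with a step of a 1.4-fold lower number from compound 3 to compound 4 (0.16 log units; within the scatter) that is expected to be small or within the scatter. In this assay compound 4 is expected to give about 10000 nM, within a range from 3000 nM to 40000 nM.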

Compound 4, half-maximal inhibitory concentration: 21800 nM
For compound 4 the middle estimate is 2.2-fold (0.34 log units) below the measured one, and the stated range covers the measured number.
By their numbers in this assay, from the lowest: compounds 3, 4, 1 and 2 (each within the scatter of the next, the first and the last beyond it).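

In this assay, going by these compounds alone, the exchange of 3-chlorophenyl for 1H-indol-3-yl on a double-bonded chain carbon bound to a double-bonded ring carbon gives a 1.5-fold higher number from compound 3 to compound 4 (0.18 log units; within the scatter) and is the first reading of one aromatic group replaced by another at this position, where the earlier step concerned only an alkyl change. So this position accepts a second aromatic ring and a hydrogen-bond donor, with the loss of the chlorine, without a shift beyond the scatter. Nothing available explains this result.

From the compounds shown here alone, whether a group carrying an amine or a carboxylic acid at this position would stay in the same range remains open. Within the data shown here, the single step alters ring count, donor count and chlorine together and cannot separate them, so what each contributes is also unresolved.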